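The source may report more compounds than this note shows. Statements on the series, on what has been measured and on what is new or still open speak of the compounds shown alone.

Measured compounds:
compound 1, `C=C1C(=O)OC[C@H]1CCOC(=O)Nc1cccc(Br)c1`, 590 nM
compound 2, `C=C1C(=O)OC[C@@H]1CCOC(=O)Nc1ccc(F)cc1F`, 700 nM
compound 3, `C=C1C(=O)OC[C@@H]1CCOC(=O)Nc1cccc(Br)c1`, 840 nM

In a functional assay on RAW264.7 cells (Mus musculus) for inhibition, with a stated time of 30 min (on this read-out lower numbers stand for stronger inhibition and higher numbers for weaker inhibition), compound 1 gives 590 nM, the lowest of the three numbers, but compound 2 at 700 nM and compound 3 at 840 nM both lie within the usual scatter of it, so the three cannot really be told apart. Within the data shown here, the one step that can be followed, a 1.4-fold higher number from compound 1 to compound 3 (0.15 log units; within the scatter), rests on (the fact that compounds 1 and 3 differ only in the configuration as drawn); the drawn configuration at the ring carbon makes no difference beyond the scatter.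

Compound 4, `C=C1C(=O)OC[C@H]1CCOC(=O)Nc1ccccc1`, keeps the core and the carbamate of compound 1 and changes only the aromatic ring: hydrogen in place of bromo on an aromatic carbon. Among the measured compounds shown here, no measured pair bears on removing the bromo group; the only step available concerns the configuration and stayed within the scatter. With nothing pointing either way, a small step is expected, and the estimate stays close to compound 1 with a wide range. The expected step of a 1.7-fold higher number from compound 1 to compound 4 (0.23 log units; within the scatter) is small. Compound 4 is therefore estimated at 1000 nM, with a likely range from 400 nM to 2500 nM.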

Compound 4, half-maximal inhibitory concentration: 390 nM
Compound 4: the middle estimate sits 2.6-fold (0.41 log units) above what was measured; measured number outside the range, below it.
By their numbers in this assay, from the lowest: compounds 4, 1, 2 and 3 (each within the scatter of the next, the first and the last beyond it).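

In this assay the bromo group turns out not to be needed at this place on the aromatic ring: the step is a 1.5-fold lower number from compound 1 to compound 4 (0.18 log units; within the scatter) and cannot be told apart from repeat-measurement noise. So a single heavy atom can leave this carbon, with hydrogen taking its place, without any visible loss of inhibition, and the ring without the bromo group serves as well as the ring with it. Nothing available here bears on why this exchange leaves the read-out unmoved.

As far as these compounds go, whether this carbon tolerates anything other than hydrogen and bromo stays open, for example an amine, a carboxylic acid or a methoxy group. Also open, from the compounds shown here alone, is whether the ring without the bromo group would behave the same with the opposite configuration drawn at the saturated ring carbon.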